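A Ring Swap on Compound 2 and Its Expected Efficacy

This account rests on a few compounds, and the source may have more. Where it says the series, first, only, none or still open, it means among the compounds named here.

Of the compounds shown here, three have been tested in an in vitro functional assay on HEK285-7 cells for antagonist activity at prostaglandin D2 receptor 2 (Homo sapiens), read by BRET and beta-arrestin recruitment; a lower number here means a smaller maximal response, a higher number a larger maximal response. Compound 1 `Nc1nc(-c2ccc(Cl)cc2)c(CC(=O)O)s1` gives 50%. Compound 2 `NS(=O)(=O)c1cccc(-c2nc(C(c3ccc(F)cc3)c3ccc(F)cc3)sc2CC(=O)O)c1` gives 55%, and compound 3 `O=C(O)Cc1sc(C(c2ccccc2)c2ccccn2)nc1-c1ccc(Cl)cc1` gives 55%. Compound 2 is level with compound 3 at the digits shown, and together they hold the highest of the three numbers; compound 1 lies a few points lower, which falls within the usual scatter, so no real ranking can be read among them.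

Compound 4 `O=C(O)Cc1sc(C(c2ccc(F)cc2)c2ccc(F)cc2)nc1-c1ccnc(O)c1` has not yet been measured in this assay. It differs from compound 2 in one place: 2-hydroxypyridin-4-yl in place of 3-sulfamoylphenyl on an aromatic carbon. Within the data shown here, no two measured compounds differ in just one place, so there is no measured step to lean on. The three measured compounds sit within the scatter of one another, so the expected step of no change at the digits printed from compound 2 to compound 4 (within the scatter) is none beyond the scatter. For compound 4 the estimate is 55%, with a range from 40% to 70%.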

Compound 4, largest response reached (reported as efficacy), in percent of the reference or control that the assay uses: 60%
The estimate for compound 4 lay 5 percentage points below the measured number, and the stated range covers the measured number.
By their numbers in this assay, from the lowest: compounds 1, 2, 3 and 4 (each within the scatter of the next).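

In this assay, among these compounds, putting 2-hydroxypyridin-4-yl in place of 3-sulfamoylphenyl gives a number 5 percentage points higher from compound 2 to compound 4 (within the scatter), the first measured step at this position. On this aromatic carbon, then, the ring of carbon only with its sulfamoyl group can be exchanged for a six-membered aromatic ring with one hetero atom, and fewer heavy atoms, without a change beyond the scatter. Nothing shown gives a reason for this result.

As far as these compounds go, whether a morpholine ring or a plain methyl group would be tolerated on this carbon stays open. So does whether the hydroxy group or the ring nitrogen of the entering group matters on its own.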